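A few compounds are considered here, and "the series" means these few. Any claim that something is new, unique, unknown or untested is made for them only; others in the source may bear on it.

Measured compounds and their values:

Compound 1 `CC1=C(N2CC2)C(=O)C(N2CC2)=C(N2CC2)C1=O` gives 6.77 in a functional assay on L1210 cells (Mus musculus), with a stated time of 12 days; a lower number here means a less potent compound, a higher number a more potent compound, by a factor of ten per unit of this negative logarithm.
Compound 2 `CC1=C(N2CC2)C(=O)C(COc2ccccc2)=C(N2CC2)C1=O` gives 5.15 in this assay.
Compound 3 `CCC1=C(N2CC2)C(=O)C(CC)=C(N2CC2)C1=O` gives 5.46 in this assay.

Among these three, compound 2 stands lowest in this assay. Its nearest neighbour is compound 3, which lies somewhat higher, a gap that is beyond the usual scatter, and compound 1 lies far above it, also well beyond the scatter.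

The unmeasured compound 4 `COCCC1=C(N2CC2)C(=O)C(C)=C(N2CC2)C1=O` keeps the shared core of compound 2 with its two aziridine rings and differs from it in a single place: methoxymethyl in place of phenoxy on a saturated chain carbon bound to a double-bonded ring carbon. Going by the values given here, no step between two measured compounds matches this change, so its effect can only be guessed from what the three values show. Compound 3, which carries only short chains on the core, sits a little above compound 2 in this assay, which suggests that replacing the larger phenoxy group with the smaller methoxymethyl group is more likely to raise than to lower the number, though perhaps only by a small amount.

Compound 4 is therefore expected to give about 5.5 in this assay, within a range of 4.9 to 6.1. The step this estimate means, a number 0.35 log units higher from compound 2 to compound 4 (beyond the scatter), is expected to be a modest rise, close to the edge of the scatter.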

Compound 4, logarithm of the reciprocal of the active concentration, log(1/C): 5.57
Compound 4: the middle estimate sits 0.07 log units below what was measured, within the range that was stated.
By their numbers in this assay, from the lowest: compound 2; then compounds 3 and 4 (each within the scatter of the next); then compound 1.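

In this assay, methoxymethyl in place of phenoxy on a saturated chain carbon bound to a double-bonded ring carbon gives a number 0.42 log units higher from compound 2 to compound 4 (beyond the scatter), the first single-place change read at this position; it shows that the number responds to the group held there, even though the entering and leaving groups each carry 1 hydrogen-bond acceptor and 0 donors. 2-Methoxyethyl in place of aziridin-1-yl on a double-bonded ring carbon gives a number 1.20 log units lower from compound 1 to compound 4 (beyond the scatter), a large step against the modest one at the chain carbon, so losing this aziridine ring costs far more than the phenoxy exchange gains. Nothing shown gives a reason for either step.

The phenoxy exchange removes an aromatic ring and also goes from 7 heavy atoms to 3, so the compounds shown cannot tell which of these two differences goes with the rise. Also open, as far as these compounds go, is how a dimethylamino group, a carboxylic acid or a longer alkyl chain on the same saturated chain carbon would read in this assay.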